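The source may hold more compounds than are shown below. What is called first, only, known or untested is meant among the compounds shown, and "the series" means these compounds.

Series so far:
compound 1 `CC1=C(N2CC2)C(=O)C(C(C)C)=C(N2CC2)C1=O` — 4.96
compound 2 `CC(C)C1=C(N2CC2)C(=O)C=C(N2CC2)C1=O` — 5.16

In a functional assay on L1210 cells (Mus musculus), with a stated time of 1 days (on this read-out higher numbers stand for higher potency (the scale is a negative logarithm) and lower numbers for lower potency), compound 2 gives 5.16, the higher of the two numbers, with compound 1 nearest and the step of a number 0.20 log units higher from compound 1 to compound 2 (within the scatter) within the scatter. Compound 3 `CC(C)C1=C(N2CC2)C(=O)C(C(C)C)=C(N2CC2)C1=O` is not yet measured. Relative to compound 2 the change is isopropyl in place of hydrogen on a double-bonded ring carbon. Going by the values given here, the only step that bears on this place is the one between compound 1 and compound 2, which runs the other way and was small, so no change beyond the scatter is expected in this assay. Compound 3 is estimated at 5 (range 4.6 to 5.4), an expected step of a number 0.16 log units lower from compound 2 to compound 3 (within the scatter).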

Compound 3, logarithm of the reciprocal of the active concentration, log(1/C): 4.36
Compound 3: the middle estimate sits 0.64 log units above what was measured; the whole stated range lies above it.
By their numbers in this assay, from the lowest: compound 3; then compounds 1 and 2 (each within the scatter of the next).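

In this assay, a number 0.80 log units lower from compound 2 to compound 3 (beyond the scatter) comes with isopropyl in place of hydrogen on the double-bonded ring carbon, and a number 0.60 log units lower from compound 1 to compound 3 (beyond the scatter) comes with isopropyl in place of methyl. Hydrogen and methyl at this carbon stayed within the scatter of each other, so isopropyl is the first group here to shift the number beyond the scatter. No measurement at hand accounts for this shift. Still open, on these data alone, is whether an ethyl group at this carbon reads with methyl or with isopropyl, and how a methoxy group or an amine there would read.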